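Trimming One Methyl from the Aryl Group

This account rests on a few compounds, and the source may have more. Where it says the series, first, only, none or still open, it means among the compounds named here.

Measured compounds in an assay on HEK293 cells for inhibition of Voltage-dependent T-type calcium channel subunit alpha-1G (Homo sapiens), read by patch clamp; on this read-out higher numbers stand for weaker inhibition and lower numbers for stronger inhibition:
compound 1 `CCCc1nc(-c2ccccc2)c(CNCCN2CCN(c3ccc(Cl)cc3)CC2)o1` gives 2820 nM
compound 2 `CCCc1nc(-c2ccccc2)c(CNCCN2CCN(c3ccc(C(F)(F)F)cc3)CC2)o1` gives 1300 nM
compound 3 `CCCc1nc(-c2ccccc2)c(CNCCN2CCN(c3cccc(C)c3C)CC2)o1` gives 1710 nM

The three compounds share one core and differ only in the aryl group on the ring amine. For the measured compounds named here, the only step past the scatter is a 2.2-fold lower number from compound 1 to compound 2 (0.34 log units; beyond the scatter). Compound 3 sits between the other two on the numbers, but a 1.6-fold lower number from compound 1 to compound 3 (0.22 log units; within the scatter) and a 1.3-fold higher number from compound 2 to compound 3 (0.12 log units; within the scatter) both stay within the scatter, so nothing separates compound 3 from either neighbour.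

Compound 4 `CCCc1nc(-c2ccccc2)c(CNCCN2CCN(c3ccccc3C)CC2)o1` is the next step from compound 3: hydrogen in place of methyl on an aromatic carbon. Going by the values given here, no measured step removes a substituent from this aryl group; all three known steps exchange one aryl group for another, and even the largest of them, from compound 1 to compound 2, is only modest. On that basis a small step is expected in this assay, if any, and the direction cannot be read from the data; a slight rise in the number is estimated, a 1.2-fold higher number from compound 3 to compound 4 (0.09 log units; within the scatter), but a value on either side of compound 3 would be unsurprising. Compound 4 is therefore expected to give about 2100 nM, with a likely range from 1000 nM to 4500 nM.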

Compound 4, half-maximal inhibitory concentration: 4300 nM
Compound 4: middle estimate off by 2.0-fold (0.31 log units), on the low side; the measured number falls inside the stated range.
By their numbers in this assay, from the lowest: compounds 2, 3, 1 and 4 (each within the scatter of the next, the first and the last beyond it).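

In this assay, for the compounds shown here, this is the first step that removes a substituent from the aryl group rather than exchanging one aryl group for another, and the methyl on this aromatic carbon, ortho to a methyl group, proves to count: a 2.5-fold higher number from compound 3 to compound 4 (0.40 log units; beyond the scatter) is modest but lies beyond the scatter. The change also alters how the compounds separate, for compound 3 could not be told from compound 2, while the 2-methylphenyl group gives a 3.3-fold higher number from compound 2 to compound 4 (0.52 log units; beyond the scatter) and so stands clear of the 4-(trifluoromethyl)phenyl group, yet a 1.5-fold higher number from compound 1 to compound 4 (0.18 log units; within the scatter) leaves it within the scatter of the 4-chlorophenyl group. No measurement at hand gives a reason for the effect of this methyl.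

It stays open whether a methyl is specifically what this position favours, since an ethyl, a methoxy or a chloro group in its place is not among the compounds shown. Also open, on these data alone, is how an unsubstituted phenyl ring would read, with the remaining methyl gone as well, and so whether that methyl counts in the same way.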